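From 4-bromophenyl to phenyl on compound 2

This account rests on a few compounds, and the source may have more. Where it says the series, first, only, none or still open, it means among the compounds named here.

In a functional assay on MCF7 cells (Homo sapiens) for antiproliferative activity, read by MTT assay, with a stated time of 48 h (a lower number here means a stronger inhibitor, a higher number a weaker inhibitor), compound 1 `COc1cccc(C(=O)Nc2nnc(/C=C/c3cc(OC)c(OC)c(OC)c3Br)s2)c1` gives 170 nM, compound 2 `COc1cc(/C=C/c2nnc(NC(=O)c3ccc(Br)cc3)s2)c(Br)c(OC)c1OC` gives 320 nM and compound 3 `COc1ccc(/C=C/c2nnc(NC(=O)c3ccccc3OC)s2)cc1OC` gives 540 nM. The value of compound 2 lies within the usual scatter of both other values, so it cannot be ranked against either of them.

Compound 4 `COc1cc(/C=C/c2nnc(NC(=O)c3ccccc3)s2)c(Br)c(OC)c1OC` has not yet been measured. It departs from compound 2 by one change, hydrogen in place of bromo on an aromatic carbon, para to a large group, which turns the 4-bromophenyl into phenyl.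

Among the measured compounds shown here, only one measured step touches this group. That step is a 1.9-fold higher number from compound 1 to compound 2 (0.27 log units; within the scatter), with 4-bromophenyl in place of 3-methoxyphenyl on a carbonyl carbon, and it stays within the scatter. For the measured compounds named here, compound 3 differs from the others in more than one place and supplies no step. Going by the values given here, no measured pair shows the loss of this bromo on its own, so the evidence is thin.

Resting on the step from compound 1, no shift beyond the scatter is expected in this assay, and no direction can be favoured. The expected step is a 1.1-fold lower number from compound 2 to compound 4 (0.03 log units; within the scatter). For compound 4 the estimate is 300 nM, with an expected range of 120 nM to 750 nM.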

Compound 4, half-maximal inhibitory concentration: 290 nM
Estimate against measurement, compound 4: 1.0-fold (0.01 log units) above; the measured number falls inside the stated range.
By their numbers in this assay, from the lowest: compounds 1, 4, 2 and 3 (each within the scatter of the next, the first and the last beyond it).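

In this assay, among the compounds shown here, the bromo of the 4-bromophenyl group is now seen changing on its own for the first time. With hydrogen in its place (a 1.1-fold lower number from compound 2 to compound 4 (0.04 log units; within the scatter)), the step stays within the scatter, so this assay resolves no effect of losing the bromo from this carbon. The plain benzoyl compound also stays within the scatter of the 3-methoxyphenyl compound (a 1.7-fold higher number from compound 1 to compound 4 (0.23 log units; within the scatter)), so the phenyl, 4-bromophenyl and 3-methoxyphenyl versions of this group cannot be told apart here, although the earlier step alone had compared only the two substituted forms. No measurement of any property is available to account for this result.

Going by these compounds, only hydrogen, bromo and methoxy appear on this ring, so it remains open whether an amine, a carboxylic acid or a longer chain such as butoxy would move the number beyond the scatter. The other bromo, shared by compound 1, compound 2 and compound 4, also remains unresolved, as compound 3 lacks it but differs from them in more than one place.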